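Swapping an Amide for Chlorine on the Benzyl Ring

The source may report more compounds than this note shows. Statements on the series, on what has been measured and on what is new or still open speak of the compounds shown alone.

Measured compounds:
- compound 1 `O=c1ccc(-c2ccc3cn[nH]c3c2)cn1Cc1ccccc1C(F)(F)F`: 100 nM
- compound 2 `NC(=O)c1cccc(Cn2cc(-c3ccc4cn[nH]c4c3)ccc2=O)c1`: 106 nM
- compound 3 `Nc1n[nH]c2cc(-c3ccc(=O)n(Cc4ccccc4F)c3)ccc12`: 4 nM

All three share a core carrying a benzyl group whose substituent varies. In an assay for inhibition of MAP kinase-interacting serine/threonine-protein kinase 2 (Homo sapiens), read by luminescence and ADP-Glo, with a stated time of 2 h (on this read-out higher numbers stand for weaker inhibition and lower numbers for stronger inhibition), compound 2 gives 106 nM, the highest of the three numbers. Compound 1 sits closest to it with 100 nM, a gap that lies within the usual scatter, so the two cannot be told apart. Compound 3, which also carries an amino group on the core, gives 4 nM, a gap well beyond the scatter.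

Compound 4 `O=c1ccc(-c2ccc3cn[nH]c3c2)cn1Cc1cccc(Cl)c1` has not yet been measured. It differs from compound 2 in one place: chloro in place of carbamoyl on an aromatic carbon. Among the compounds with values here, no measured pair shows exactly this swap, so the expectation rests on what is available. Compound 1 and compound 2 carry quite different benzyl substituents yet give numbers within the scatter of each other, which suggests this position tolerates change without a large shift. For compound 4 the expected step of a 1.3-fold lower number from compound 2 to compound 4 (0.12 log units; within the scatter) is therefore small, most likely within the scatter, with a slight lean toward a lower number. Compound 4 is estimated at 80 nM, within a range from 25 nM to 300 nM.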

Compound 4, half-maximal inhibitory concentration: 40 nM
Estimate against measurement, compound 4: 2.0-fold (0.30 log units) above, and the stated range covers the measured number.
By their numbers in this assay, from the lowest: compound 3; then compound 4; then compounds 1 and 2 (each within the scatter of the next).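

In this assay, within the data shown here, replacing carbamoyl with chloro on this aromatic carbon gives a 2.7-fold lower number from compound 2 to compound 4 (0.42 log units; beyond the scatter) as the only step that changes just one place, so it isolates the effect of the substituent on the benzyl ring. It shows that the choice of group on this carbon can move the number beyond the usual scatter, although the step is modest, and that a carbamoyl group, with its 1 hydrogen-bond donor and 1 hydrogen-bond acceptor, is not required here for inhibition at this level, since chloro, which has neither, gives the lower number. No measurement here accounts for the size or direction of this shift.

The compounds shown leave open whether the lower number comes from the presence of chlorine or simply from the absence of carbamoyl, a question that a bare hydrogen, a methyl, a nitrile or a carboxylic acid on the same carbon could help to settle. They also leave open whether the same swap would give a similar step on the core bearing the amino group.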